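Ring Size Change Repeated on a Second Core

A few compounds are considered here, and "the series" means these few. Any claim that something is new, unique, unknown or untested is made for them only; others in the source may bear on it.

Three of the four compounds have been measured in a physicochemical assay for lipophilicity; on this read-out lower numbers stand for lower lipophilicity and higher numbers for higher lipophilicity. Compound 2 `CC(C)=CCC/C(C)=C/CC/C(C)=C/CSC[C@H](NC(=O)CCCCCN1CCCC1)C(=O)NC1CCCC1` gives 4.04. Compound 1 `CC(C)=CCC/C(C)=C/CC/C(C)=C/CSC[C@H](NC(=O)CCCCCN1CCCC1)C(=O)NC1CCCCC1` differs from compound 2 by cyclohexyl in place of cyclopentyl on an amide-type nitrogen; in this assay compound 1 gives 4.48, a step of a number 0.44 log units higher from compound 2 to compound 1 (beyond the scatter). Compound 3 `CC(C)=CCC/C(C)=C/CC/C(C)=C/CSC[C@H](NC(=O)CCCCCN1CCN(C)CC1)C(=O)NC1CCCC1` carries a different core, which differs from that of compound 2 by 4-methylpiperazin-1-yl in place of pyrrolidin-1-yl on a saturated chain carbon, five bonds along the chain from a carbonyl carbon, and compound 3 gives 4.55, a step of a number 0.51 log units higher from compound 2 to compound 3 (beyond the scatter). The values of compound 3 and compound 1 lie within the scatter of each other.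

Compound 4 `CC(C)=CCC/C(C)=C/CC/C(C)=C/CSC[C@H](NC(=O)CCCCCN1CCN(C)CC1)C(=O)NC1CCCCC1` is not yet measured. It differs from compound 3 by cyclohexyl in place of cyclopentyl on an amide-type nitrogen, the same change already seen from compound 2 to compound 1, at the same place. Among the measured compounds shown here, the step from compound 3 to compound 4 in this assay is expected to be a number 0.44 log units higher from compound 3 to compound 4 (beyond the scatter), because the one earlier instance of this change gave a number 0.44 log units higher from compound 2 to compound 1 (beyond the scatter). This expectation rests on that single pair alone, so its uncertainty is taken somewhat wider than the usual scatter. Compound 4 is estimated at 4.99, with a likely range from 4.65 to 5.35.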

Compound 4, distribution coefficient: 4.99
The estimate for compound 4 equals the measured number at the digits printed; the range from low to high includes it.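

In this assay, cyclohexyl in place of cyclopentyl on an amide-type nitrogen gives a number 0.44 log units higher from compound 3 to compound 4 (beyond the scatter), the same size at the digits printed as a number 0.44 log units higher from compound 2 to compound 1 (beyond the scatter), so in these two pairs the change carries from the core of compound 2 to the core of compound 3 without any difference in size. The other new step, a number 0.51 log units higher from compound 1 to compound 4 (beyond the scatter), matches a number 0.51 log units higher from compound 2 to compound 3 (beyond the scatter), but it comes from the same four compounds and is the same agreement read the other way, not a separate test, so the result rests on two cores and one ring change and does not show that the step holds across the series. No data are given that bear on what lies behind the size of this step.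

The compounds shown leave open whether the step keeps its size on a core ending in morpholin-4-yl or a dimethylamino group, or with a shorter chain. They also leave open what cycloheptyl or an open-chain hexyl group would give on the same amide-type nitrogen.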